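Swapping the Halogenated Phenyl Tail of Compound 3

The source may report more compounds than this note shows. Statements on the series, on what has been measured and on what is new or still open speak of the compounds shown alone.

Three measured compounds share one core and differ only in the aryl group at the end of a double-bonded chain. Compound 1 `COc1ccc(OC)c(/C=C/C(=O)Nc2cc3c(Nc4ccc(F)c(Cl)c4)ncnc3cc2O[C@H]2CCOC2)c1` gives 36300 nM in a functional assay on MCF7 cells (Homo sapiens) for cytotoxicity, read by MTT assay, with a stated time of 72 h; a higher number here means a weaker inhibitor, a lower number a stronger inhibitor; compound 2 `COc1ccc(/C=C/C(=O)Nc2cc3c(Nc4ccc(F)c(Cl)c4)ncnc3cc2O[C@H]2CCOC2)c(OC)c1OC` gives 4650 nM; compound 3 `O=C(/C=C/c1cc(Br)c(O)c(Br)c1)Nc1cc2c(Nc3ccc(F)c(Cl)c3)ncnc2cc1O[C@H]1CCOC1` gives 30600 nM, the second highest of the three numbers. The steps run a 7.8-fold lower number from compound 1 to compound 2 (0.89 log units; beyond the scatter), a 1.2-fold lower number from compound 1 to compound 3 (0.07 log units; within the scatter) and a 6.6-fold higher number from compound 2 to compound 3 (0.82 log units; beyond the scatter). Compound 4 `O=C(/C=C/c1ccc(F)cc1Cl)Nc1cc2c(Nc3ccc(F)c(Cl)c3)ncnc2cc1O[C@H]1CCOC1` carries 2-chloro-4-fluorophenyl in place of 3,5-dibromo-4-hydroxyphenyl on a double-bonded chain carbon bound to a double-bonded chain carbon. Among the measured compounds shown here, no measured step covers this new aryl group; the steps around compound 3 show that only the 2,3,4-trimethoxyphenyl group lowers the number, while the other two aryl groups sit close together. A step of about a 1.2-fold lower number from compound 3 to compound 4 (0.09 log units; within the scatter) is therefore expected, within the scatter. Compound 4 is estimated at 25000 nM, with a range from 8000 nM to 80000 nM.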

Compound 4, half-maximal inhibitory concentration: 26200 nM
Beside the measured number, compound 4's estimate is 1.0-fold (0.02 log units) below it; the measured number falls inside the stated range.
By their numbers in this assay, from the lowest: compound 2; then compounds 4, 3 and 1 (each within the scatter of the next).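

Putting 2-chloro-4-fluorophenyl in place of 3,5-dibromo-4-hydroxyphenyl gives a 1.2-fold lower number from compound 3 to compound 4 (0.07 log units; within the scatter) in this assay, so this change, which also leaves no hydrogen-bond donor on the group, does not separate the two compounds; a 1.4-fold lower number from compound 1 to compound 4 (0.14 log units; within the scatter) likewise stays within the scatter. With a 5.6-fold higher number from compound 2 to compound 4 (0.75 log units; beyond the scatter), the 2,3,4-trimethoxyphenyl group remains the only one of the four that stands apart. Nothing measured here explains this grouping. Still open, from the compounds shown here alone, is whether an aryl group carrying an amine or a carboxylic acid would stand apart in the same way.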